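Thiophen-3-yl in place of chlorophenyl on the amide carbonyl

The compounds below may be only part of what the source reports. "The series", "measured", "known", "first", "only" and "open" are said of these compounds alone.

Two compounds share one core and differ only in the group on the carbonyl carbon. Compound 1 `O=C(Nc1cc(-c2ccccc2)nn1-c1ccccc1)c1cnccn1` carries pyrazin-2-yl there, and in an assay on isolated protein with metabotropic glutamate receptor 5 (Rattus norvegicus) as the target (a lower number here means that less compound is needed, a higher number that more compound is needed for the effect), compound 1 gives 400 nM. Compound 2 `O=C(Nc1cc(-c2ccccc2)nn1-c1ccccc1)c1ccc(Cl)cc1` carries 4-chlorophenyl instead, and in this assay compound 2 gives 100 nM, the lowest of the two numbers measured; the step of a 4.0-fold lower number from compound 1 to compound 2 (0.60 log units; beyond the scatter) shows the size of that gap. Compound 3 `O=C(Nc1cc(-c2ccccc2)nn1-c1ccccc1)c1ccsc1` is not yet measured. It differs from compound 2 by thiophen-3-yl in place of 4-chlorophenyl on a carbonyl carbon. Among the compounds with values here, the only measured step that bears on this change is the one from compound 1 to compound 2, where a six-membered aromatic ring with two hetero atoms was exchanged for the chlorophenyl; the thiophene now entering stands somewhere between those two groups in what is counted. Compound 3 is therefore expected to give a number somewhat higher than compound 2, by a step of a 2.0-fold higher number from compound 2 to compound 3 (0.30 log units; within the scatter), which is of modest size and may not pass beyond the scatter. The estimate for compound 3 is 200 nM, with a range from 80 nM to 500 nM.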

Compound 3, half-maximal effective concentration: 2900 nM
Compound 3: the middle estimate sits 15-fold (1.16 log units) below what was measured; measured number outside the range, above it.
By their numbers in this assay, from the lowest: compound 2; then compound 1; then compound 3.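

Going from 4-chlorophenyl to thiophen-3-yl on the carbonyl carbon brings a 29-fold higher number from compound 2 to compound 3 (1.46 log units; beyond the scatter) in this assay and is the largest step seen so far, so this place responds far more strongly to the choice of ring than the earlier pair showed. Thiophen-3-yl does not fall between the other two groups, as a 7.3-fold higher number from compound 1 to compound 3 (0.86 log units; beyond the scatter) places it beyond pyrazin-2-yl as well, so among these three compounds the number does not follow the count of ring hetero atoms, with compound 1 going against such an order. No measurement at hand explains why this ring gives so high a number.

From the compounds shown here alone, what a plain phenyl or a chlorothiophene would give at this place stays open. So does whether the chlorine or the six-membered carbon ring matters more for the low number of compound 2.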